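Phenyl in place of trifluoromethyl: a growth inhibition step

The source may report more compounds than this note shows. Statements on the series, on what has been measured and on what is new or still open speak of the compounds shown alone.

Compound 1 `C/C(=N/O)c1ccc(NC(=O)Cn2nc(C(F)(F)F)nc2N)cc1` gives 10.5% in a functional assay on CCRF-CEM cells (Homo sapiens) for inhibition, read by sulforhodamine B assay, with a stated time of 48 h, tested at 10 uM; on this read-out lower numbers stand for less inhibition of growth and higher numbers for more inhibition of growth at the one concentration tested
Compound 2 `COc1cc(-c2nc3sc(-c4ccccc4)cn3n2)cc(OC)c1OC` gives 49% in this assay
Compound 3 `COc1cc(-c2nc(N)n(CC(=O)Nc3ccc(/C(C)=N\O)cc3)n2)cc(OC)c1OC` gives 15.5% in this assay

Compound 1 and compound 3 lie within the scatter of each other, while compound 2 stands above compound 1 by more than the scatter. Compound 4 `C/C(=N/O)c1ccc(NC(=O)Cn2nc(-c3ccccc3)nc2N)cc1` has phenyl in place of trifluoromethyl on an aromatic carbon. Among the compounds with values here, no measured pair shows this change directly. Compound 3 also carries a six-membered aromatic ring at that place and gives 15.5%, so no step beyond the scatter is expected in this assay. A slight upward a number 4.5 percentage points higher from compound 1 to compound 4 (within the scatter) is expected. Compound 4 is estimated at 15%, with an expected range from 5% to 30%.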

Compound 4, percent growth inhibition at one concentration: 6.77%
Compound 4: middle estimate off by 8.2 percentage points, on the high side, and the stated range covers the measured number.
By their numbers in this assay, from the lowest: compounds 4, 1 and 3 (each within the scatter of the next); then compound 2.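

In this assay, within the data shown here, replacing trifluoromethyl with phenyl on this aromatic carbon gives a number 3.7 percentage points lower from compound 1 to compound 4 (within the scatter), the first direct reading of this change at this position. At the one concentration tested, the read-out therefore does not separate the two groups, although only phenyl brings a six-membered aromatic ring. No measured information bears on the reason for this result. As far as these compounds go, whether an amine, a carboxylic acid or a longer chain on this aromatic carbon would shift growth inhibition beyond the scatter remains open.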